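Aminothiophene ketone series: single-concentration activity readings

The source may hold more compounds than are shown below. What is called first, only, known or untested is meant among the compounds shown, and "the series" means these compounds.

Measured so far:
compound 1 `Nc1scc(CN2CCN(c3cccnc3)CC2)c1C(=O)c1ccc(Cl)cc1`: -2.7%
compound 2 `Nc1scc(CN2CCN(c3ccc(C(F)(F)F)cc3)CC2)c1C(=O)c1cccc(C(F)(F)F)c1`: -27%

In a functional assay on CHO cells with adenosine receptor A1 (Homo sapiens) as the target, read by cAMP accumulation and immunoassay, with a stated time of 6 min, tested at 1 uM (a higher number here means a weaker effect of the compound at the concentration tested, a lower number a stronger effect), compound 1 stands at the highest of the two numbers; compound 2 lies lower, beyond the scatter. Compound 3 `Nc1scc(CN2CCN(c3cc(Cl)ccc3Cl)CC2)c1C(=O)c1ccc(Cl)cc1` is not yet measured. It differs from compound 1 in one place: 2,5-dichlorophenyl in place of pyridin-3-yl on an amine nitrogen in a ring. For the measured compounds named here, no measured pair shows this change, so its size is unknown here. A modest step toward lower numbers is expected, close to the scatter, resting only on compound 2 at -27% carrying carbon-only rings. For compound 3 the estimate is -12%, within -35% to 10%, an expected step of a number 9.3 percentage points lower from compound 1 to compound 3 (within the scatter).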

Compound 3, a percentage reported as activity, at one concentration (the size of the read-out at that concentration, not a potency): -42%
The estimate for compound 3 lay 30 percentage points above the measured number; measured number below the stated range.
By their numbers in this assay, from the lowest: compound 3; then compound 2; then compound 1.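

In this assay, for the compounds shown here, 2,5-dichlorophenyl in place of pyridin-3-yl on an amine nitrogen in a ring gives a number 39.3 percentage points lower from compound 1 to compound 3 (beyond the scatter) and is the first single-place change readable. The size of the step shows that the read-out at this concentration depends on the aromatic group at this position. Nothing available explains the step.

Going by these compounds, it remains open whether the step follows the two chlorine atoms or the carbon-only ring. Unsubstituted phenyl at this position would separate the two, and a single chlorine would show whether both chlorine atoms are needed.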